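Series notes: compound 3 to compound 4

A few compounds are considered here, and "the series" means these few. Any claim that something is new, unique, unknown or untested is made for them only; others in the source may bear on it.

Measured so far:
compound 1 `O=C(/C=C/c1ccccc1Cl)Nc1ccc2ncnc(Nc3cccc(Br)c3)c2c1`: 2 ug/mL
compound 2 `COc1ccccc1/C=C/C(=O)Nc1ccc2ncnc(Nc3cccc(Br)c3)c2c1`: 1.28 ug/mL
compound 3 `O=C(/C=C/c1ccc(Cl)cc1)Nc1ccc2ncnc(Nc3cccc(Cl)c3)c2c1`: 9.97 ug/mL

In a functional assay on B16-F10 cells (Mus musculus) for inhibition, read by MTT assay, with a stated time of 48 h (a lower number here means a stronger inhibitor, a higher number a weaker inhibitor), compound 3 stands highest of the three numbers, beyond the scatter from both others. Compound 4 `O=C(/C=C/c1ccccc1Cl)Nc1ccc2ncnc(Nc3cccc(Cl)c3)c2c1` differs from compound 3 by 2-chlorophenyl in place of 4-chlorophenyl on a double-bonded chain carbon bound to a double-bonded chain carbon. Going by the values given here, no measured step covers this change; the one measured step, a 1.6-fold lower number from compound 1 to compound 2 (0.19 log units; within the scatter), alters a different group on that ring and is within the scatter. Compound 1 carries the 2-chlorophenyl and compound 3 the 4-chlorophenyl, but the two also differ in the halogen on the other aryl group, so their values only suggest a lower number with the 2-chlorophenyl. A downward step a 2.8-fold lower number from compound 3 to compound 4 (0.45 log units; beyond the scatter) is therefore expected, with wide uncertainty. Compound 4 is estimated at 3.5 ug/mL, between 1.2 ug/mL and 10 ug/mL.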

Compound 4, half-maximal inhibitory concentration: 1.74 ug/mL
The estimate for compound 4 lay 2.0-fold (0.30 log units) above the measured number, within the range that was stated.
By their numbers in this assay, from the lowest: compounds 2, 4 and 1 (each within the scatter of the next); then compound 3.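

In this assay 2-chlorophenyl in place of 4-chlorophenyl gives a 5.7-fold lower number from compound 3 to compound 4 (0.76 log units; beyond the scatter) as a direct comparison with the rest of the structure unchanged, so the location of the chloro on this ring matters in this pair. Chloro in place of bromo on an aromatic carbon gives a 1.1-fold lower number from compound 1 to compound 4 (0.06 log units; within the scatter) and does not separate these two compounds when 2-chlorophenyl is present. No evidence is available to explain either result.

Going by these compounds, whether the step between 4-chlorophenyl and 2-chlorophenyl also holds with bromo on the other aryl group remains open. Also open, on these data alone, is how an amine or a carboxylic acid on this phenyl ring would compare.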